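Swapping the anilide ring of compound 3 for a pyrimidine

The source may report more compounds than this note shows. Statements on the series, on what has been measured and on what is new or still open speak of the compounds shown alone.

The measured compounds and their numbers:
- compound 1, `CCc1cccc(NC(=O)CN2CCN(c3ccccn3)CC2)c1`, gives 67.9 nM in an assay on HEK293 cells for displacement of a labelled ligand from D(4) dopamine receptor (Homo sapiens), read by scintillation counting, with a stated time of 60 min; a lower number here means a stronger inhibitor, a higher number a weaker inhibitor
- compound 2, `Cc1ccc(C2CCN(CC(=O)Nc3cccc(C)c3)CC2)nc1`, gives 41.7 nM in this assay
- compound 3, `CCc1cccc(NC(=O)CN2CCN(c3ccc(Cl)cn3)CC2)c1`, gives 172 nM in this assay

Among these three, compound 3 stands at the highest number, meaning the weakest binder of the set; compound 1 is nearest to it and compound 2 furthest.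

Among the measured compounds shown here, the one step that can be traced within the set is a 2.5-fold higher number from compound 1 to compound 3 (0.40 log units; beyond the scatter). It concerns a chloro group on the pyridine ring, not the amide side of the molecule, so it does not bear on the change considered now.

Compound 4, `O=C(CN1CCN(c2ccc(Cl)cn2)CC1)Nc1cncnc1`, differs from compound 3 in the group on the amide nitrogen: pyrimidin-5-yl in place of 3-ethylphenyl on an amide-type nitrogen. For the measured compounds named here, no measured pair in this set covers a change of this kind, so the expectation rests on the general observation that replacing an all-carbon aromatic ring by a smaller nitrogen-containing ring is a sizeable alteration. For compound 4 the number in this assay is expected to rise, with a 3.5-fold higher number from compound 3 to compound 4 (0.54 log units; beyond the scatter) as the estimated step. The estimated value for compound 4 is 600 nM, with a range from 150 nM to 2500 nM.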

Compound 4, inhibition constant: > 50000 nM
Compound 4: no number, only a limit; the forecaster's own chance of this, stated with the estimate: 10%; middle value at least 83-fold (1.92 log units) away from the limit.
By their numbers in this assay, from the lowest: compounds 2 and 1 (each within the scatter of the next); then compound 3. At a limit, above all of these: compound 4.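

Among the compounds shown here, the group on the amide-type nitrogen turns out to matter far more than anything the earlier compounds could reveal: in this assay, pyrimidin-5-yl in place of 3-ethylphenyl gives an at least 290-fold higher number from compound 3 to compound 4 (2.46 log units; beyond the scatter). For the compounds shown here, the only earlier step, on the other side of the molecule, was much smaller at a 2.5-fold higher number from compound 1 to compound 3 (0.40 log units; beyond the scatter). Compound 4 has no exact value, and its result is only a limit of the assay: the limit of > 50000 nM in this assay, at which 1 of the 4 values shown sits.

Since this single swap removes the ethyl group and also brings two ring nitrogens into the aromatic ring, the compounds shown cannot tell which of these changes accounts for the loss. On these data alone, an unsubstituted phenyl ring or a pyridin-3-yl ring on the same amide-type nitrogen would help separate the two, and how either would read remains open.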